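The source may report more compounds than this note shows. Statements on the series, on what has been measured and on what is new or still open speak of the compounds shown alone.

Measured in an ADME assay on cells (spleen, Mus musculus, strain C57BL/6) for inhibition, read by flow cytometry and propidium iodide staining, with a stated time of 24 h, at 37 degrees C (on this read-out higher numbers stand for an effect only at larger amounts of compound and lower numbers for an effect already at smaller amounts), with values as follows:
compound 1 `O=C(Cn1cc(CCCCO)nn1)NCc1ccccc1` gives 1700 uM
compound 2 `Nc1ccc(-c2cn(CC(=O)NCc3ccccc3)nn2)cc1` gives 1240 uM

Within the data shown here, compound 2 stands within the scatter of compound 1, the only other measured compound. Compound 3 `COc1ccc(-c2cn(CC(=O)NCc3ccccc3)nn2)cc1` is still unmeasured and differs from compound 2 by methoxy in place of amino on an aromatic carbon, para to a large group (methoxy in place of amino on an aromatic carbon). Among the measured compounds shown here, the only measured step (a 1.4-fold lower number from compound 1 to compound 2 (0.14 log units; within the scatter)) exchanged a whole substituent on the shared core, and no measured step replaces amino itself, so support is thin. No step beyond the scatter is therefore expected in this assay, in either direction (a 1.0-fold higher number from compound 2 to compound 3 (0.02 log units; within the scatter)). Compound 3 is estimated at 1300 uM (expected range 600 uM to 2800 uM).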

Compound 3, concentration for half-maximal effect: "non-toxic" (no number reported)
Compound 3: no number reported; no gap can be computed for the estimate.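

In this assay, among these compounds, compound 3 gives "non-toxic" (no number reported) and carries no number, so no step from compound 2 to compound 3 can be read. The size of any effect of 4-methoxyphenyl in place of 4-aminophenyl stays open, and no measurement here bears on an explanation.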